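The source may report more compounds than this note shows. Statements on the series, on what has been measured and on what is new or still open speak of the compounds shown alone.

Compound 1, `CCCCCCCCCCCCNC(=O)[C@@H]1CSC(c2ccc(NC(C)=O)cc2)N1`, gives 2400 nM in a functional assay on cells (Homo sapiens) for antiproliferative activity, read by sulforhodamine B assay, with a stated time of 48 h; a higher number here means a weaker inhibitor, a lower number a stronger inhibitor. Compound 2, `CCCCCCCCCCCCCCCNC(=O)[C@@H]1CSC(c2ccc(NC(C)=O)cc2)N1`, gives 1600 nM in this assay, and the step of a 1.5-fold lower number from compound 1 to compound 2 (0.18 log units; within the scatter) leaves the two compounds standing together, neither separated from the other beyond the scatter. Compound 3, `CCCCCCCCCCCCCCCCCNC(=O)[C@@H]1CSC(c2ccc(NC(C)=O)cc2)N1`, carries the change (ethyl in place of hydrogen on a saturated chain carbon, ten or more bonds along the chain from an amide-type nitrogen). Within the data shown here, the only step that bears on it is the earlier chain extension, a 1.5-fold lower number from compound 1 to compound 2 (0.18 log units; within the scatter), which stayed within the scatter, so no step beyond the scatter is expected for compound 3 in this assay. Compound 3 is accordingly estimated at 1300 nM, within 500 nM to 3500 nM, the expected step being a 1.2-fold lower number from compound 2 to compound 3 (0.09 log units; within the scatter).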

Compound 3, half-maximal inhibitory concentration: 8500 nM
Compound 3: middle estimate off by 6.5-fold (0.82 log units), on the low side; the measured number lies above the stated range.
By their numbers in this assay, from the lowest: compounds 2 and 1 (each within the scatter of the next); then compound 3.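

Among these compounds, at this place on the chain, extension is not without effect: ethyl in place of hydrogen gives a 5.3-fold higher number from compound 2 to compound 3 (0.73 log units; beyond the scatter) in this assay, the first step here beyond the scatter. Pentyl in place of hydrogen likewise gives a 3.5-fold higher number from compound 1 to compound 3 (0.55 log units; beyond the scatter), so compound 3 stands apart from both compound 1 and compound 2, which stay within the scatter of each other. Nothing available here explains this reversal. Still open, as far as these compounds go, is how a longer chain would read, and whether an amine or a carboxylic acid in place of the ethyl would restore the lower numbers.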